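The source may hold more compounds than are shown below. What is called first, only, known or untested is meant among the compounds shown, and "the series" means these compounds.

Measured so far:
compound 1 `Nc1sc2c(c1C(=O)NCc1ccccc1)CCN(Cc1ccccc1)C2` – 13100 nM
compound 2 `Nc1sc2c(c1C(=O)NCc1cccc(Cl)c1)CCN(Cc1ccccc1)C2` – > 20000 nM

Both compounds were tested in an in vitro assay on CHOk1 cells with adenosine receptor A1 (Homo sapiens) as the target; a higher number here means that more compound is needed for the effect, a lower number that less compound is needed. Compound 1 gives 13100 nM. For compound 2 the result is only a limit, > 20000 nM, so where compound 2 stands is known only as the limit of > 20000 nM in this assay, at which 1 of the 2 values shown sits. Going by the values given here, the one measured step, an at least 1.5-fold higher number from compound 1 to compound 2 (0.18 log units; that floor lies within the scatter), is a chloro in place of hydrogen on an aromatic carbon.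

Compound 3 `NC(=O)c1c(N)sc2c1CCN(Cc1ccccc1)C2` is not yet measured. It differs from compound 2 by hydrogen in place of 3-chlorobenzyl on an amide-type nitrogen. Among the compounds with values here, no measured step touches the amide-type nitrogen, so the change from the (3-chlorobenzyl)amino to the amino group has no precedent among the measured compounds, and the step to expect in this assay cannot be read from them in either direction. Compound 3 is therefore estimated at 15000 nM, with a range from 3000 nM to 60000 nM, which means an expected step of an at least 1.3-fold lower number from compound 2 to compound 3 (0.12 log units; that floor lies within the scatter).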

Compound 3, half-maximal effective concentration: > 20000 nM
Compound 3: only a limit was reported; the forecaster's own chance of this, stated with the estimate: 45%; at least 1.3-fold (0.12 log units) between middle value and limit.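

The amide nitrogen now has a measured step: the result is an at least 1.5-fold higher number from compound 1 to compound 3 (0.18 log units; that floor lies within the scatter) for hydrogen in place of benzyl on this nitrogen. Removing the benzyl group therefore brings no readable gain in this assay for compound 3, but a floor inside the scatter does not set compound 3 apart from compound 1 either. The step between compound 2 and compound 3 cannot be read because both results are limits, and the series now gathers at a single value: the limit of > 20000 nM in this assay, at which 2 of the 3 values shown sit.

From the compounds shown here alone, how far compound 2 and compound 3 lie past that limit stays open. So does how a methyl or a phenethyl group on the amide nitrogen would read in this assay and whether either would fall within the measurable range.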